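Aryl sulfone notes: removing fluorine from compound 2

A few compounds are considered here, and "the series" means these few. Any claim that something is new, unique, unknown or untested is made for them only; others in the source may bear on it.

In a functional assay on A2780 cells (Homo sapiens) for inhibition, read by sulforhodamine B assay, with a stated time of 72 h (a higher number here means a weaker inhibitor, a lower number a stronger inhibitor), compound 1 `O=C(NCc1ccc(S(=O)(=O)c2ccccc2)cc1)c1cc2ccncc2s1` gives 14 nM and compound 2 `O=C(NCc1ccc(S(=O)(=O)c2cc(F)cc(F)c2)cc1)c1cnc2nccn2c1` gives 3 nM as the lower of the two numbers, a gap beyond the usual scatter. The two differ in more than one place, so this gap cannot be assigned to any single change. Compound 3 `O=C(NCc1ccc(S(=O)(=O)c2ccccc2)cc1)c1cnc2nccn2c1` keeps the rest of compound 2 and brings one change, phenyl in place of 3,5-difluorophenyl on a sulfonyl sulfur. For the measured compounds named here, no measured pair isolates this change. Compound 1 also carries phenyl on the sulfonyl sulfur and gives 14 nM on a different core, so a large loss in this assay is not expected. The estimated 2.0-fold higher number from compound 2 to compound 3 (0.30 log units; within the scatter) is a modest rise in the number, near the edge of the scatter. Compound 3 is expected at 6 nM with an estimated range of 2 nM to 20 nM for repeated measurements.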

Compound 3, half-maximal inhibitory concentration: 68 nM
Estimate against measurement, compound 3: 11-fold (1.05 log units) below, and the stated range ends below it.
By their numbers in this assay, from the lowest: compound 2; then compound 1; then compound 3.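

With the core held fixed, phenyl in place of 3,5-difluorophenyl on a sulfonyl sulfur gives a 23-fold higher number from compound 2 to compound 3 (1.36 log units; beyond the scatter) in this assay, so this position strongly affects the number on this core, which compound 1 alone could not show. With phenyl held on the sulfonyl sulfur, the group on the carbonyl carbon also matters: the exchange gives a 4.9-fold higher number from compound 1 to compound 3 (0.69 log units; beyond the scatter), a smaller step than the one at the sulfonyl sulfur, and the core of compound 1 gives the lower number of the two. Nothing measured here explains the size of either step.

On these data alone, it remains open whether 3,5-difluorophenyl brings a similar step on the core of compound 1. As far as these compounds go, it also remains open how 3-fluorophenyl or 3,5-dichlorophenyl on the sulfonyl sulfur would compare with compound 2 and compound 3.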